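Pyridyl isomer swap on the oxazole ketone series

This account rests on a few compounds, and the source may have more. Where it says the series, first, only, none or still open, it means among the compounds named here.

Measured compounds:
compound 1 `CCCCCCCC/C=C\CCCCCCCC(OC)OC` — > 300000 nM
compound 2 `CCCCCCCC/C=C\CCCCCCC(=O)c1ncc(-c2ccccn2)o1` — 18 nM
compound 3 `CCCCCCCC/C=C\CCCCCCC(=O)c1ccccn1` — > 100000 nM

Going by the values given here, in an assay on isolated protein for inhibition of Fatty-acid amide hydrolase 1 (Homo sapiens) (a lower number here means a stronger inhibitor, a higher number a weaker inhibitor), compound 2 gives 18 nM, the only number in the set. Compound 1 gives only a limit, > 300000 nM (the limit of > 300000 nM in this assay, at which 1 of the 3 values shown sits). Compound 3 likewise gives only a limit, > 100000 nM (the limit of > 100000 nM in this assay, at which 1 of the 3 values shown sits). The step that the two limits leave unreadable from compound 1 to compound 3 is therefore of unreadable size, and it concerns the chain end rather than the pyridyl group. Compound 4 `CCCCCCCC/C=C\CCCCCCC(=O)c1ncc(-c2cccnc2)o1` differs from compound 2 by pyridin-3-yl in place of pyridin-2-yl on an aromatic carbon. Among the compounds with values here, no measured step bears on this change, so no size can be read from the set. Compound 4 is expected to keep measurable activity with a modest weakening, a 3.3-fold higher number from compound 2 to compound 4 (0.52 log units; beyond the scatter), and is estimated at 60 nM, with a range from 15 nM to 300 nM.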

Compound 4, inhibition constant: 61 nM
Estimate against measurement, compound 4: 1.0-fold (0.01 log units) below; the measured number falls inside the stated range.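

In this assay, going by these compounds alone, pyridin-3-yl in place of pyridin-2-yl, on the aromatic carbon next to the ring oxygen, gives a 3.4-fold higher number from compound 2 to compound 4 (0.53 log units; beyond the scatter) as the first readable step at this position. Both isomers carry a measured number, so the position accepts either pyridyl attachment at a modest cost. The earlier compounds shown here, which lack the substituted five-membered ring, offered no comparison of this kind.

As far as these compounds go, how a pyridin-4-yl or a plain phenyl group would read at this position remains open. Nothing among the data shown explains the size of this step.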